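A second 4-methylphenyl on the nitrogen-bound carbon

A few compounds are considered here, and "the series" means these few. Any claim that something is new, unique, unknown or untested is made for them only; others in the source may bear on it.

Of the compounds shown here, two of one shared core have been measured in an assay on Prostate gland for inhibition of steroid 5-alpha-reductase (Rattus norvegicus); on this read-out higher numbers stand for weaker inhibition and lower numbers for stronger inhibition. Compound 1 `C/C(=C\C(=O)Nc1ccccc1OCCCC(=O)O)c1ccc2c(ccn2CC(C)C)c1` gives 160 nM in this assay, and compound 2 `C/C(=C\C(=O)Nc1ccccc1OCCCC(=O)O)c1ccc2c(ccn2Cc2ccc(C)cc2)c1` gives 88 nM. Within the data shown here, the one step between them, a 1.8-fold lower number from compound 1 to compound 2 (0.26 log units; within the scatter), separates them by less than the scatter of repeated measurements, so neither compound can be called the stronger inhibitor. Among the measured compounds shown here, compound 2 carries the lower of the two numbers, and its only neighbour, compound 1, stands within the scatter of it.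

Compound 3 `C/C(=C\C(=O)Nc1ccccc1OCCCC(=O)O)c1ccc2c(ccn2C(c2ccc(C)cc2)c2ccc(C)cc2)c1` has not yet been measured in this assay. It differs from compound 2 by 4-methylphenyl in place of hydrogen on a saturated chain carbon bound to an aromatic carbon and an aromatic nitrogen, so the carbon that already carries one 4-methylphenyl receives a second. For the measured compounds named here, the only measured step, a 1.8-fold lower number from compound 1 to compound 2 (0.26 log units; within the scatter), touched the same carbon and stayed within the scatter; no measured pair shows what a second aromatic ring at this place does. On that basis compound 3 is expected to give a number near that of compound 2, with the step of a 1.3-fold higher number from compound 2 to compound 3 (0.10 log units; within the scatter) not clearly beyond the scatter. The estimate for compound 3 is 110 nM, within 30 nM to 400 nM.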

Compound 3, half-maximal inhibitory concentration: 8.8 nM
Estimate against measurement, compound 3: 13-fold (1.10 log units) above, outside the stated range (below it).
By their numbers in this assay, from the lowest: compound 3; then compounds 2 and 1 (each within the scatter of the next).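

Among these compounds, the carbon bound to an aromatic carbon and an aromatic nitrogen proves able to carry a clear change in this assay: placing 4-methylphenyl there in place of hydrogen gives a 10-fold lower number from compound 2 to compound 3 (1.00 log units; beyond the scatter), the only step in this set that lies beyond the scatter. The earlier change on this carbon, a 1.8-fold lower number from compound 1 to compound 2 (0.26 log units; within the scatter), stayed within the scatter, so that step alone gave no sign that this position could shift the number, whereas a second 4-methylphenyl on the same carbon does so. Nothing available here bears on the reason for this step.

The compounds shown leave open whether the lower number depends on the second ring, on its methyl group or on the two rings being alike. A second group on this carbon such as plain phenyl, 4-chlorophenyl or cyclohexyl would address this, and a methyl group as the second substituent would show whether a ring is needed there at all.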